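Swapping the aryl group on the oxazole: compound 1 to 4

The compounds below may be only part of what the source reports. "The series", "measured", "known", "first", "only" and "open" are said of these compounds alone.

Measured compounds in an ADME assay on Huh7.5.1 cells (Homo sapiens) for cytotoxicity, read by ATP content, with a stated time of 48 h; a lower number here means that less compound is tolerated, a higher number that more compound is tolerated:
- compound 1, `Cc1oc(-c2c(F)cccc2F)nc1CN1CCC(C(=O)NCCCN2C[C@H](C)C[C@H](C)C2)CC1`, 32700 nM
- compound 2, `CC[C@@H]1C[C@H](CC)CN(CCCNC(=O)C2CCN(Cc3nc(-c4c(F)cccc4F)oc3C)CC2)C1`, 12600 nM
- compound 3, `Cc1cccc(Cl)c1-c1nc(CN2CCC(C(=O)NCCCN3CCC(C(C)C)CC3)CC2)c(C)o1`, 4910 nM

Compound 1 stands at the highest number of the three; compound 2 is nearest and compound 3 furthest. Within the data shown here, the one step with a single change, a 2.6-fold lower number from compound 1 to compound 2 (0.41 log units; beyond the scatter), alters the piperidine on the saturated chain, not the aryl group. Compound 3 differs from compound 1 in two places, so its number says little about either change alone.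

The new compound 4, `Cc1ccc(-c2nc(CN3CCC(C(=O)NCCCN4C[C@H](C)C[C@H](C)C4)CC3)c(C)o2)cc1C`, differs from compound 1 as follows: 3,4-dimethylphenyl in place of 2,6-difluorophenyl on an aromatic carbon. Among the measured compounds shown here, no measured step touches this position, so the data give no direct guide to its size or direction. For the measured compounds named here, since the only single-change step was modest and the other compounds sit lower than compound 1, compound 4 is expected to come in somewhat lower, at 20000 nM (range 8000 nM to 55000 nM), a step of a 1.6-fold lower number from compound 1 to compound 4 (0.21 log units; within the scatter) that is expected to be small.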

Compound 4, half-maximal cytotoxic concentration: 6910 nM
Beside the measured number, compound 4's estimate is 2.9-fold (0.46 log units) above it; measured number outside the range, below it.
By their numbers in this assay, from the lowest: compounds 3, 4 and 2 (each within the scatter of the next, the first and the last beyond it); then compound 1.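

The aryl position on the five-membered aromatic ring with 1 nitrogen and 1 oxygen, untouched by the earlier step, proves to matter in this assay: 3,4-dimethylphenyl in place of 2,6-difluorophenyl gives a 4.7-fold lower number from compound 1 to compound 4 (0.68 log units; beyond the scatter). Like the change on the saturated chain, a 2.6-fold lower number from compound 1 to compound 2 (0.41 log units; beyond the scatter), this step lies beyond the scatter, so the number for compound 1 responds to changes at both of these places. Nothing available explains why the number falls with this aryl swap.

The swap alters both the kind of substituent and where it sits on the phenyl ring, and these two changes cannot be told apart here. Compounds carrying 2,6-dimethylphenyl or 3,4-difluorophenyl on the core of compound 1 would separate them.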